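A Side-Chain Swap in an Oral Tail Flick Series

A few compounds are considered here, and "the series" means these few. Any claim that something is new, unique, unknown or untested is made for them only; others in the source may bear on it.

Three compounds have been measured in a functional assay on the whole organism (Tail, strain ICR) with Mus musculus as the target, in the tail flick test, with a stated time of 90 min, at a dose of 25 umol/kg by the oral route; a lower number here means a weaker effect, a higher number a stronger effect of the compound at the dose given:

Compound 1 `O=C(CN(c1nc(Cl)nc2[nH]cnc12)C1CC1)NCC(=O)OCc1ccccc1`: 27.2%
Compound 2 `N=C(N)NCCC[C@H](NC(=O)CN(c1nc(Cl)nc2[nH]cnc12)C1CC1)C(=O)O`: 27.6%
Compound 3 `N=C(N)NCCC[C@H](NC(=O)CN(c1nc(Cl)nc2[nH]cnc12)C1CC1)C(=O)OCc1ccccc1`: 30.4%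

Compound 2 stands second highest of these three numbers, yet its gap to compound 1, its nearest, and to compound 3, its furthest, both lie within the scatter, so the three are indistinguishable. Compound 4 `NC(=O)C[C@H](NC(=O)CN(c1nc(Cl)nc2[nH]cnc12)C1CC1)C(=O)O` differs from compound 2 in one place: a group of 3 heavy atoms (1 carbon, 1 nitrogen, 1 oxygen; no ring) in place of a group of 6 heavy atoms (3 carbon, 3 nitrogen; no ring), on a saturated chain carbon, two bonds along the chain from an amide-type nitrogen and a carbonyl carbon. For the measured compounds named here, no measured step makes exactly this change. The closest is the step of a number 3.2 percentage points higher from compound 1 to compound 3 (within the scatter), which adds the very group that here departs; it lies within the scatter, as does a number 2.8 percentage points higher from compound 2 to compound 3 (within the scatter). A step of a number 0.6 percentage points lower from compound 2 to compound 4 (within the scatter) is therefore expected, none beyond the scatter. For compound 4 the estimated value is 27%, with a range from 17% to 37%.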

Compound 4, a percentage reported as activity, at one dose (the size of the read-out at that dose, not a potency): 20.1%
Compound 4: middle estimate off by 6.9 percentage points, on the high side; the range from low to high includes it.
By their numbers in this assay, from the lowest: compounds 4, 1, 2 and 3 (each within the scatter of the next, the first and the last beyond it).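

For the compounds shown here, with the carboxylic acid kept in place, the side chain alone changes here for the first time: in this assay, carbamoyl in place of the larger group gives a step (a number 7.5 percentage points lower from compound 2 to compound 4 (within the scatter)). Going by these compounds alone, this is the largest single-place step so far, yet it remains within the scatter, so this pair alone cannot separate the change at this chain carbon from no change at all. Nothing available explains the step. The compounds shown leave open whether an amine or a longer chain ending in carbamoyl on this carbon would give a step beyond the scatter. They also leave open how a benzyl ester of compound 4 would compare with compound 4.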